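Solubility notes: ether for amine on the shared core

The compounds below may be only part of what the source reports. "The series", "measured", "known", "first", "only" and "open" are said of these compounds alone.

Measured in a physicochemical assay for solubility, read by HPLC, using the shake flask method, measured as kinetic solubility, with a stated time of 2 h, at pH 7.4; a higher number here means a more soluble compound, a lower number a less soluble compound:
Compound 1 `Cc1cc(NCc2ccccn2)n2ncc(-c3ccc(F)cc3)c2n1`: < 5000 nM, a limit of the assay.
Compound 2 `Cc1cc(NCc2ccccn2)n2ncc(Br)c2n1`: 89300 nM.
Compound 3 `Cc1cc(NCc2cccnc2)n2nc(C)c(-c3ccccc3)c2n1`: 110000 nM.

Compound 3 holds the highest of the two numbers in this assay, though its value and that of compound 2 lie within the scatter of each other. Compound 1 reports only a limit (the limit of < 5000 nM in this assay, at which 1 of the 3 values shown sits). Going by the values given here, the one measured step, an at least 17-fold higher number from compound 1 to compound 2 (1.25 log units; beyond the scatter), concerns a different part of the core and does not touch the group that changes here.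

Compound 4 `Cc1cc(OCc2ccccn2)n2nc(C)c(-c3ccccc3)c2n1` differs from compound 3 by (pyridin-2-yl)methoxy in place of ((pyridin-3-yl)methyl)amino on an aromatic carbon. No measured pair in this set changes that position, so nothing shown sets the size of the step. The change swaps an amine-linked pyridin-3-ylmethyl for an ether-linked pyridin-2-ylmethyl; absent any comparable step, the expectation is a modest decrease at most, possibly within the scatter. Compound 4 is estimated at 50000 nM in this assay, between 15000 nM and 120000 nM, which means an expected step of a 2.2-fold lower number from compound 3 to compound 4 (0.34 log units; beyond the scatter).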

Compound 4, solubility: 25600 nM
Estimate against measurement, compound 4: 2.0-fold (0.29 log units) above; measured number inside the range.
By their numbers in this assay, from the lowest: compound 4; then compounds 2 and 3 (each within the scatter of the next). At a limit, below all of these: compound 1.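

In this assay, going by these compounds alone, (pyridin-2-yl)methoxy in place of ((pyridin-3-yl)methyl)amino gives the first measured step at this position: a 4.3-fold lower number from compound 3 to compound 4 (0.63 log units; beyond the scatter). The earlier step lay in a different part of the core, so the read-out now proves responsive at this position too, in a swap that takes the count of hydrogen-bond donors from 1 to 0. No available measurement bears on the cause of this step.

From the compounds shown here alone, the swap changes the linking atom and the place of the pyridine nitrogen together, so the share of each remains open, and a (pyridin-3-yl)methoxy group on the core of compound 3 would separate the two. Going by these compounds, how a carboxylic acid or a longer chain at this position would read in this assay also remains open.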